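Bombesin receptor subtype-3 series: branched alkyl in place of aryl

The source may hold more compounds than are shown below. What is called first, only, known or untested is meant among the compounds shown, and "the series" means these compounds.

Measured so far:
compound 1 `O=C(O)c1ccccc1-c1ccc(CCc2ncc(CCC3CCCCC3)[nH]2)cc1`, 33 nM
compound 2 `O=C(O)c1ccccc1-c1ccc(CCc2ncc(Cc3cccc(Cl)c3)[nH]2)cc1`, 31 nM
compound 3 `Cc1cccc(Cc2cnc(CCc3ccc(-c4ccccc4C(=O)O)cc3)[nH]2)c1`, 75 nM

In an in vitro functional assay on cells for agonist activity at Bombesin receptor subtype-3 (Mus musculus), read by luminescence and calcium flux (a lower number here means that less compound is needed, a higher number that more compound is needed for the effect), compound 3 stands highest of the three; a 2.3-fold higher number from compound 1 to compound 3 (0.36 log units; beyond the scatter) and a 2.4-fold higher number from compound 2 to compound 3 (0.38 log units; beyond the scatter) both run beyond the scatter, while a 1.1-fold lower number from compound 1 to compound 2 (0.03 log units; within the scatter) does not. Compound 4 `CCC(C)(CC)Cc1cnc(CCc2ccc(-c3ccccc3C(=O)O)cc2)[nH]1` carries the change (1-ethyl-1-methylpropyl in place of 3-methylphenyl on a saturated chain carbon bound to an aromatic carbon). The step bearing on it is a 2.3-fold higher number from compound 1 to compound 3 (0.36 log units; beyond the scatter), where a saturated group on the same chain carbon gave a modestly lower number than the 3-methylphenyl of compound 3. Compound 4 is expected to follow that direction: a modest step down, a 1.9-fold lower number from compound 3 to compound 4 (0.27 log units; within the scatter), given that compound 1 gives 33 nM. The estimate for compound 4 is 40 nM, within 15 nM to 110 nM.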

Compound 4, half-maximal effective concentration: 30 nM
For compound 4 the middle estimate is 1.3-fold (0.12 log units) above the measured one, within the range that was stated.
By their numbers in this assay, from the lowest: compounds 4, 2 and 1 (each within the scatter of the next); then compound 3.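

At the saturated chain carbon bound to an aromatic carbon, 1-ethyl-1-methylpropyl carries no ring, yet it gives a lower number than the 3-methylphenyl group (a 2.5-fold lower number from compound 3 to compound 4 (0.40 log units; beyond the scatter)), so a ring in this group is not required for a number in this range. Compound 4 stands level with the two other groups (a 1.0-fold lower number from compound 2 to compound 4 (0.01 log units; within the scatter); a 1.1-fold lower number from compound 1 to compound 4 (0.04 log units; within the scatter)). No measurement on hand explains this result.

Open, as far as these compounds go, is whether a shorter group such as isopropyl keeps the number at this position. Also open, from the compounds shown here alone, is how an amine or hydroxyl on the 1-ethyl-1-methylpropyl group would read.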